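This account rests on a few compounds, and the source may have more. Where it says the series, first, only, none or still open, it means among the compounds named here.

Measured so far in an assay on membranes from brain (Cavia porcellus) for binding affinity to Sigma non-opioid intracellular receptor 1 (Homo sapiens); a higher number here means a weaker inhibitor, a lower number a stronger inhibitor:
compound 1 `CCN(CC)CCNS(=O)(=O)c1ccc(Br)cc1`: compound 1 gives 10.1 nM
compound 2 `CCN(CC)CCNS(=O)(=O)c1ccc(I)cc1`: compound 2 gives 4.97 nM
compound 3 `CN(CCN1CCCCCC1)S(=O)(=O)c1ccc(I)cc1`: compound 3 gives 0.14 nM

Compound 2 and compound 1 differ in one place, (bromo in place of iodo on an aromatic carbon), and that step reads a 2.0-fold higher number from compound 2 to compound 1 (0.31 log units; beyond the scatter). Compound 3 stands lowest of the three; between its core and that of compound 2 the difference is not broken down here. Compound 4 `CN(CCN1CCCCCC1)S(=O)(=O)c1ccc(Br)cc1` carries the same change on the core of compound 3: bromo in place of iodo on an aromatic carbon. Among the measured compounds shown here, for compound 4 the expected step in this assay is a 2.0-fold higher number from compound 3 to compound 4 (0.30 log units; within the scatter), about the size of the earlier one, because the single earlier instance of this change gave a 2.0-fold higher number from compound 2 to compound 1 (0.31 log units; beyond the scatter). Compound 4 is accordingly estimated at 0.28 nM, with a range from 0.12 nM to 0.65 nM.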

Compound 4, inhibition constant: 0.18 nM
Beside the measured number, compound 4's estimate is 1.6-fold (0.19 log units) above it; low and high end bracket the measured number.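

In this assay, bromo in place of iodo on an aromatic carbon gives a 1.3-fold higher number from compound 3 to compound 4 (0.11 log units; within the scatter), so the two halogens cannot be told apart on this core. Set beside the earlier instance, the step does not differ measurably between the two cores: the same change on two cores in this assay, a 2.0-fold higher number (0.31 log units; beyond the scatter) from compound 2 to compound 1 and a 1.3-fold higher number (0.11 log units; within the scatter) from compound 3 to compound 4, 1.6-fold (0.20 log units) apart, within the scatter of two such steps
Among the compounds shown here, this agreement rests on only two pairs, so it does not show that the step would hold on any other core, and it gives no reason for its size.

The compounds shown leave open what a chloro, fluoro or methoxy group would do in place of the halogen on the shared aromatic ring. They also leave open whether an amine or a carboxylic acid there would follow the same course on both cores.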